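The source may hold more compounds than are shown below. What is called first, only, known or untested is meant among the compounds shown, and "the series" means these compounds.

Working notes on the series, read in a functional assay on KBVIN cells (Homo sapiens) for antiproliferative activity, read by sulforhodamine B assay, with a stated time of 3 days; on this read-out lower numbers stand for an effect already at smaller amounts and higher numbers for an effect only at larger amounts of compound. Compound 1 `CCCc1ccc(-c2cc(=O)c3c(o2)C(CC)(CC)C(=O)C(CC)=C3O)cc1` gives 12.2 uM, and compound 2 `CCC1=C(O)c2c(oc(-c3ccc(O)cc3)cc2=O)C(CC)(CC)C1=O` gives 20.6 uM. For the measured compounds named here, these are the only two numbers so far and they lie within the scatter of each other, so compound 2 holds no distinct rank.

The next step leads to compound 3 `CCC1=C(O)c2c(oc(-c3ccc(F)cc3)cc2=O)C(CC)(CC)C1=O`, with fluoro in place of hydroxy on an aromatic carbon, para to a large group: fluoro in place of hydroxy on an aromatic carbon. Going by the values given here, one measured step bears on this change: a 1.7-fold higher number from compound 1 to compound 2 (0.23 log units; within the scatter), with hydroxy in place of propyl on an aromatic carbon. Among the compounds with values here, that single step stayed within the scatter, but one pair is thin support and no measured compound yet carries fluoro. In this assay, no step beyond the scatter is therefore expected in either direction. The expected size of the change is a 1.4-fold lower number from compound 2 to compound 3 (0.14 log units; within the scatter), which would remain within the scatter. Compound 3 is expected at 15 uM, with an estimated range of 7 uM to 30 uM.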

Compound 3, concentration for half-maximal effect: 1.85 uM
Compound 3: middle estimate off by 8.1-fold (0.91 log units), on the high side; the measured number lies below the stated range.
By their numbers in this assay, from the lowest: compound 3; then compounds 1 and 2 (each within the scatter of the next).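

In this assay this position proves sensitive to its substituent: the change from 4-hydroxyphenyl to 4-fluorophenyl gives an 11-fold lower number from compound 2 to compound 3 (1.05 log units; beyond the scatter) and fluoro in place of propyl on the same aromatic carbon gives a 6.6-fold lower number from compound 1 to compound 3 (0.82 log units; beyond the scatter) as the second step beyond the scatter. The earlier pair could not show this, since hydroxy and propyl, para to a large group, leave compound 1 and compound 2 within the scatter of each other, whereas fluoro sets compound 3 apart from both and gives it the lowest number of the three. Nothing at hand explains why fluoro separates from hydroxy and propyl at this position.

With only three groups shown on this aromatic carbon, it remains open whether the lower number is particular to fluoro or would also appear with chloro, bromo, methoxy or trifluoromethyl in the same place. On these data alone, it also remains open whether fluoro would keep a step of this size at another carbon of the ring or with the ethyl groups of the shared core replaced by methyl groups.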